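This account rests on a few compounds, and the source may have more. Where it says the series, first, only, none or still open, it means among the compounds named here.

Measured in a functional assay on HCT-116 cells (Homo sapiens) for inhibition, read by MTT assay, with a stated time of 72 h (a higher number here means a weaker inhibitor of growth, a lower number a stronger inhibitor of growth), so far:

Compound 1 `O[C@H](COCCOC[C@@H](O)Cc1cn(-c2cccs2)nn1)Cc1ccc(-c2ccccc2)cc1` — 33400 nM
Compound 2 `COC1=C(C)C(=O)C(CCCCCCCCCCn2cc(C[C@H](O)COCCOC[C@@H](O)Cc3ccc(-c4ccccc4)cc3)nn2)=C(C)C1=O` — 4000 nM
Compound 3 `COC1=C(OC)C(=O)C(CCCCCCCCCCCCCCCn2cc(C[C@H](O)COCCOC[C@@H](O)Cc3ccc(-c4ccccc4)cc3)nn2)=C(C)C1=O` — 1500 nM

Compound 1 has the highest number of the three; compound 2 and compound 3 both sit well beyond the scatter below it, each carrying a long chain with a quinone at the triazole nitrogen where compound 1 has thiophen-2-yl. Compound 4 `O[C@H](COCCOC[C@@H](O)Cc1cn(-c2cncc3ccccc23)nn1)Cc1ccc(-c2ccccc2)cc1` keeps the shared core of compound 1 and changes only the group on that aromatic nitrogen: isoquinolin-4-yl in place of thiophen-2-yl on an aromatic nitrogen. Within the data shown here, no measured pair isolates this kind of change, so the expectation leans on compound 1 alone. The larger aromatic group is expected to shift the number somewhat, most likely downward, with a step from compound 1 to compound 4 of a 1.7-fold lower number from compound 1 to compound 4 (0.22 log units; within the scatter) expected in this assay. For compound 4 the estimate is 20000 nM, within 6000 nM to 60000 nM.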

Compound 4, concentration for 50% growth inhibition: 17800 nM
Compound 4: the middle estimate sits 1.1-fold (0.05 log units) above what was measured; the measured number falls inside the stated range.
By their numbers in this assay, from the lowest: compound 3; then compound 2; then compounds 4 and 1 (each within the scatter of the next).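

In this assay, among these compounds, isoquinolin-4-yl in place of thiophen-2-yl on an aromatic nitrogen of the five-membered aromatic ring with 3 nitrogen gives the first single-place reading at this position (a 1.9-fold lower number from compound 1 to compound 4 (0.27 log units; within the scatter)). A second aromatic ring and a larger group therefore leave the number within the scatter here. No evidence accompanies this step that could explain it.

Still open, as far as these compounds go, is whether an amine or a carboxylic acid on that nitrogen would move the number beyond the scatter. A long alkyl chain without the quinone also remains to be read at this position.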